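From Difluorobenzyl to Cyclopropylmethyl: a Stability Question

The source may report more compounds than this note shows. Statements on the series, on what has been measured and on what is new or still open speak of the compounds shown alone.

Compound 1 `CS(=O)(=O)Nc1ccc2c(c1)S(=O)(=O)N=C(C1=C(O)[C@H]3CCC[C@H]3N(Cc3ccc(F)c(F)c3)C1=O)N2` was examined in an in vitro ADME assay on microsomes from liver (Homo sapiens) for metabolic stability; on this read-out higher numbers stand for a longer-lived compound and lower numbers for a shorter-lived compound. In this assay compound 1 gives > 1 h, which is a limit of the assay rather than a number. Compound 3 `CS(=O)(=O)Nc1ccc2c(c1)S(=O)(=O)N=C(c1c(O)c3cccn3n(Cc3ccc(F)cc3)c1=O)N2` likewise reaches a limit, with > 1 h in this assay. Compound 2 `CC(C)(C)CCN1C(=O)C(C2=NS(=O)(=O)c3cc(NS(C)(=O)=O)ccc3N2)=C(O)C2CCCCC21`, built on a different core, gives 0.267 h in this assay. Two of the three results thus sit at the limit of > 1 h in this assay, at which 2 of the 3 values shown sit, and only compound 2 stands at a measured value; of compound 1 it can only be said that it stands at that limit.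

Compound 4 `CS(=O)(=O)Nc1ccc2c(c1)S(=O)(=O)N=C(C1=C(O)[C@H]3CCC[C@H]3N(CC3CC3)C1=O)N2` differs from compound 1 by cyclopropyl in place of 3,4-difluorophenyl on a saturated chain carbon bound to an amide-type nitrogen in a ring. Among the compounds with values here, no measured pair in this set carries such a change, so no step size is known for it. Starting from a limit, the change is expected to amount to an at least 1.2-fold lower number from compound 1 to compound 4 (0.09 log units; that floor lies within the scatter), which may lie within the scatter or run somewhat downward. Compound 4 is therefore expected to give about 0.8 h in this assay, with a range from 0.3 h to 1.5 h.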

Compound 4, half-life: > 1 h
Compound 4 gave a limit, no number; the forecaster's own chance of this, stated with the estimate: 40%; middle value at least 1.2-fold (0.09 log units) from the limit.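

Compound 1 and compound 4 both give a limit rather than a number in this assay, and no step can be read between them. The compounds shown leave open whether cyclopropyl in place of 3,4-difluorophenyl shifts the half-life at all, and in which direction.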